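A few compounds are considered here, and "the series" means these few. Any claim that something is new, unique, unknown or untested is made for them only; others in the source may bear on it.

Measured so far:
compound 1 `COC(=O)/C=C/c1cccc(N(Cc2ccccc2)C(=O)C2CCCCC2)c1`: > 1000 nM
compound 2 `COC/C=C/c1ccc(CN(C(=O)C2CCCCC2)c2cccc(/C=C/C(=O)OC)c2)cc1`: 233 nM

In an assay on isolated protein with Bile acid receptor (Homo sapiens) as the target (on this read-out higher numbers stand for an effect only at larger amounts of compound and lower numbers for an effect already at smaller amounts), compound 1 gives > 1000 nM, a limit of the assay rather than a number (the limit of > 1000 nM in this assay, at which 1 of the 2 values shown sits). Within the data shown here, compound 2 gives 233 nM in this assay, the only full number here. Compound 3 `COC(=O)/C=C/c1cccc(N(Cc2cc(OC)cc(OC)c2)C(=O)C2CCCCC2)c1` is not yet measured; it carries 3,5-dimethoxyphenyl in place of 4-(3-methoxyprop-1-en-1-yl)phenyl on a saturated chain carbon bound to an amide-type nitrogen. Among the measured compounds shown here, the only measured step, an at least 4.2-fold lower number from compound 1 to compound 2 (0.63 log units; beyond the scatter), introduced the very group that now leaves, so a weaker effect is expected; the two entering methoxy groups have no measured precedent here. Compound 3 is expected to give 600 nM in this assay, with a range of 200 nM to 2000 nM, meaning an estimated step of a 2.6-fold higher number from compound 2 to compound 3 (0.41 log units; beyond the scatter).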

Compound 3, half-maximal effective concentration: 606 nM
Compound 3: the middle estimate sits 1.0-fold (0.00 log units) below what was measured, and the stated range covers the measured number.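

In this assay, 3,5-dimethoxyphenyl on a saturated chain carbon bound to an amide-type nitrogen does not hold the level of 4-(3-methoxyprop-1-en-1-yl)phenyl, with a 2.6-fold higher number from compound 2 to compound 3 (0.42 log units; beyond the scatter). Against the unsubstituted phenyl, the change reads an at least 1.6-fold lower number from compound 1 to compound 3 (0.21 log units; that floor lies within the scatter), so no gain from the two methoxy groups is established. The reference compound 1 is held at a limit of the assay, not a number: the limit of > 1000 nM in this assay, at which 1 of the 3 values shown sits.

Open, from the compounds shown here alone, is how the 3-methoxyprop-1-en-1-yl chain contributes. Whether its terminal methoxy can give way to an amine or a carboxylic acid remains untested in the compounds shown.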